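Swapping methyl for methoxy on compound 3

A few compounds are considered here, and "the series" means these few. Any claim that something is new, unique, unknown or untested is made for them only; others in the source may bear on it.

Compound 1 (`COc1ccc(/C=C2\S/C(=N\c3ccccc3)N(Cc3ccco3)C2=O)cc1OC`) gives > 400000 nM (a limit)
Compound 2 (`O=C1/C(=C/c2cccc([N+](=O)[O-])c2)S/C(=N\c2ccccc2)N1Cc1ccco1`) gives "not determined" (no result reported) (no result)
Compound 3 (`Cc1ccc(/C=C2\S/C(=N\c3ccccc3)N(Cc3ccco3)C2=O)cc1`) gives 421000 nM (a number)

Within the data shown here, in a toxicity assay on CHO cells (Cricetulus griseus) for cytotoxicity, read by MTT assay, with a stated time of 48 h (on this read-out lower numbers stand for stronger inhibition and higher numbers for weaker inhibition), compound 3 gives 421000 nM as the only true number here. Compound 1 gives > 400000 nM which is a limit and not a number. Compound 4 (`COc1ccc(/C=C2\S/C(=N\c3ccccc3)N(Cc3ccco3)C2=O)cc1`) differs from compound 3 by methoxy in place of methyl on an aromatic carbon. Among the measured compounds shown here, the one measured step that bears on this change, a step that the limit leaves unreadable from compound 1 to compound 3, cannot be sized, so it offers no guide. The expectation therefore stays close to compound 3 at 421000 nM with no shift beyond the scatter in either direction. The expected step is a 1.1-fold lower number from compound 3 to compound 4 (0.02 log units; within the scatter) and it is only an estimate. Compound 4 is estimated at 400000 nM (expected range 200000 nM to 800000 nM).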

Compound 4, half-maximal inhibitory concentration: > 400000 nM
Compound 4: no number, only a limit; the forecaster's own chance of this, stated with the estimate: 40%; the middle value lies on the limit itself.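

Compound 4 gives > 400000 nM, which is a limit and not a number, and its steps from compound 3 and compound 1 cannot be read. The compounds shown leave open whether methoxy in place of methyl on an aromatic carbon shifts this read-out at all.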